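Methoxy in Place of Fluoro on Two Related Cores

The source may report more compounds than this note shows. Statements on the series, on what has been measured and on what is new or still open speak of the compounds shown alone.

Measured so far:
compound 1, `O=C(COc1c(-c2ccccc2)oc2ccccc2c1=O)Nc1ccc(F)cc1`, > 10000 nM
compound 2, `COc1ccc(NC(=O)COc2c(-c3ccccc3)oc3ccccc3c2=O)cc1`, 6740 nM
compound 3, `O=C(COc1ccc2c(=O)cc(-c3ccccc3)oc2c1)Nc1ccc(F)cc1`, 5770 nM

All three were tested in a functional assay on NCI-H661 cells (Homo sapiens) for antiproliferative activity, read by MTT assay, with a stated time of 72 h; a higher number here means a weaker inhibitor of growth, a lower number a stronger inhibitor of growth. The value of compound 1 is not a number but a limit of the assay, (the limit of > 10000 nM in this assay, at which 1 of the 3 values shown sits). Compound 1 and compound 2 share one core and differ only by methoxy in place of fluoro on an aromatic carbon, which gave an at least 1.4-fold lower number from compound 1 to compound 2 (0.17 log units; that floor lies within the scatter). Compound 3 carries a different core; how the two cores differ is not broken down here. In this assay compound 3 gives 5770 nM, which sits within the scatter of compound 2.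

The unmeasured compound 4, `COc1ccc(NC(=O)COc2ccc3c(=O)cc(-c4ccccc4)oc3c2)cc1`, is related to compound 3 by methoxy in place of fluoro on an aromatic carbon. Since the surroundings of the change read the same as for the earlier pair, this is the same change. The step is expected to be modest, a 1.4-fold lower number from compound 3 to compound 4 (0.16 log units; within the scatter), resting on the earlier pair, where compound 2 gives 6740 nM after the same change. Compound 4 is therefore estimated at 4000 nM, between 1500 nM and 9500 nM.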

Compound 4, concentration for 50% growth inhibition: 5500 nM
The estimate for compound 4 lay 1.4-fold (0.14 log units) below the measured number; the range from low to high includes it.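

In this assay, methoxy in place of fluoro on the core of compound 3 gave a 1.0-fold lower number from compound 3 to compound 4 (0.02 log units; within the scatter), so on this core the step from 4-fluorophenyl to 4-methoxyphenyl shows no change beyond the usual spread of repeated measurements. This does not show that the change carries over from one core to the other, nor that it behaves differently on each: the same change on two cores in this assay, an at least 1.4-fold lower number (0.17 log units; that floor lies within the scatter) from compound 1 to compound 2 and a 1.0-fold lower number (0.02 log units; within the scatter) from compound 3 to compound 4; the limit leaves it open whether they differ. As far as these compounds go, compound 1 stands at a limit of the assay and not at a number, so the full size of the step on its core stays unknown: the limit of > 10000 nM in this assay, at which 1 of the 4 values shown sits.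

The compounds shown hold only fluoro and methoxy at this place on the ring, which leaves open how an amine or a carboxylic acid there would read on either core. Also open, from the compounds shown here alone, is whether a longer chain in place of methoxy would move the number beyond the scatter on one core, on both or on neither.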